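Quinoline amide series: aryl swap on compound 3

The source may hold more compounds than are shown below. What is called first, only, known or untested is meant among the compounds shown, and "the series" means these compounds.

Measured so far in a functional assay on MKN-45 cells (Homo sapiens) for cytotoxicity, read by MTT assay, with a stated time of 72 h; on this read-out higher numbers stand for weaker inhibition and lower numbers for stronger inhibition:
compound 1 `COc1cccc(-c2cc(C(=O)Nc3ccc(Oc4ccnc5cc(OCCCN6CCCCC6)c(OC)cc45)c(F)c3)c3ccccc3n2)c1`: 360 nM
compound 2 `COc1cc2c(Oc3ccc(NC(=O)c4cc(-c5cccc(Cl)c5)nc5ccccc45)cc3F)ccnc2cc1OCCCN1CCCCC1`: 11 nM
compound 3 `COc1cc2c(Oc3ccc(NC(=O)c4cc(-c5cccc(Cl)c5)nc5ccccc45)cc3F)ccnc2cc1OCCCN1CCC(C)CC1`: 30 nM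

Compound 3 stands second highest of the three numbers; its nearest neighbour is compound 2, a 2.7-fold higher number from compound 2 to compound 3 (0.44 log units; beyond the scatter), while compound 1 lies furthest, a much higher number. The next compound, compound 4 `COc1cc2c(Oc3ccc(NC(=O)c4cc(-c5ccc(C)cc5)nc5ccccc45)cc3F)ccnc2cc1OCCCN1CCC(C)CC1`, differs from compound 3 in one place: 4-methylphenyl in place of 3-chlorophenyl on an aromatic carbon. Within the data shown here, only one measured step touches that aryl group, namely a 33-fold lower number from compound 1 to compound 2 (1.51 log units; beyond the scatter), which shows that what sits on this ring can move this assay strongly. Among the measured compounds shown here, no measured pair compares chloro with methyl here, and no pair compares two positions on this ring, so the direction is uncertain. Given that compound 2 and compound 3 both carry the chloro group that gave the low numbers, a move away from it is expected to raise the number for compound 4 by a 2.0-fold higher number from compound 3 to compound 4 (0.30 log units; within the scatter), a modest step at most. Compound 4 is therefore estimated at 60 nM, within 15 nM to 250 nM.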

Compound 4, half-maximal inhibitory concentration: 770 nM
Compound 4: middle estimate off by 13-fold (1.11 log units), on the low side; the measured number lies above the stated range.
By their numbers in this assay, from the lowest: compound 2; then compound 3; then compound 1; then compound 4.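

In this assay, the aryl group on the carbon next to the ring nitrogen proves as sensitive to a change of whole substituent as to the earlier swap of chloro for methoxy: 4-methylphenyl in place of 3-chlorophenyl gives a 26-fold higher number from compound 3 to compound 4 (1.41 log units; beyond the scatter). The two groups match in heavy-atom count and in their zero hydrogen-bond donors and acceptors, so those counts do not account for the large step, and the low numbers of this pair cannot be carried over to any aryl group of the same size. No measured information on the cause of this step is available.

The swap changes both the substituent and its place on the ring at once, so the share of each remains unresolved. A 3-methylphenyl or a 4-chlorophenyl group on the core of compound 3 would separate the two.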